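A few compounds are considered here, and "the series" means these few. Any claim that something is new, unique, unknown or untested is made for them only; others in the source may bear on it.

Compound 1 `Cc1cc(C)cc(S(=O)(=O)c2c(C(=O)NC(C)C(=O)NCc3ccco3)[nH]c3ccc(Cl)cc23)c1` gives 24200 nM in an ADME assay on MT4 cells (Homo sapiens) for cytotoxicity, read by MTT assay (a lower number here means that less compound is tolerated, a higher number that more compound is tolerated), the lowest of the two numbers recorded, with compound 3 `Cc1cc(C)cc(S(=O)(=O)c2c(C(=O)NCC(=O)NC(C)c3ccncc3)[nH]c3ccc(Cl)cc23)c1` nearest at 47000 nM. For compound 2 `Cc1cc(C)cc(S(=O)(=O)c2c(C(=O)NCc3cccc(N)c3)[nH]c3ccc(Cl)cc23)c1` this assay reports only a limit, > 53400 nM. Compound 4 `Cc1cc(C)cc(S(=O)(=O)c2c(C(=O)NC(C)C(=O)NCc3ccccc3F)[nH]c3ccc(Cl)cc23)c1` differs from compound 1 by 2-fluorophenyl in place of furan-2-yl on a saturated chain carbon bound to an amide-type nitrogen. Among the measured compounds shown here, no measured step changes this part of the chain alone: the steps of an at least 2.2-fold higher number from compound 1 to compound 2 (0.34 log units; beyond the scatter) and a 1.9-fold higher number from compound 1 to compound 3 (0.29 log units; within the scatter) exchange the whole side chain and move the number up, one of them within the scatter, so they give only loose guidance. Compound 4 is therefore expected to sit close to compound 1 or somewhat higher, an estimated 1.2-fold higher number from compound 1 to compound 4 (0.09 log units; within the scatter). In this assay compound 4 is estimated at 30000 nM, between 12000 nM and 70000 nM.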

Compound 4, half-maximal cytotoxic concentration: 23300 nM
Compound 4: the middle estimate sits 1.3-fold (0.11 log units) above what was measured; low and high end bracket the measured number.
By their numbers in this assay, from the lowest: compounds 4, 1 and 3 (each within the scatter of the next). At a limit, above all of these: compound 2.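

Taken alone, 2-fluorophenyl in place of furan-2-yl on a saturated chain carbon bound to an amide-type nitrogen gives a 1.0-fold lower number from compound 1 to compound 4 (0.02 log units; within the scatter) in this assay. The earlier steps shown here exchanged the whole side chain, whereas this one isolates the ring at its end, and a five-membered aromatic ring and a six-membered ring of carbon only here give values within the scatter of each other.

Going by these compounds, whether a carboxylic acid or a longer chain at this place would give a different number stays open. Compound 2 remains a limit, not a number: the limit of > 53400 nM in this assay, at which 1 of the 4 values shown sits.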